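Methyl to bromo on the aryl ether of a xanthine pair

A few compounds are considered here, and "the series" means these few. Any claim that something is new, unique, unknown or untested is made for them only; others in the source may bear on it.

Working notes on a small set of related compounds tested in an assay on brain cells (strain Sprague-Dawley) for displacement of a labelled ligand from adenosine receptor A1 (Rattus norvegicus), read by scintillation counting, with a stated time of 60 min; on this read-out higher numbers stand for weaker inhibition and lower numbers for stronger inhibition. Within the data shown here, compound 1 `CCn1c(=O)c2c(nc(COc3ccc(C)cc3)n2C)n(CC)c1=O` gives 1420 nM in this assay, the lower of the two numbers measured so far. Compound 2 `Cn1c(=O)c2c(nc(COc3ccc(Br)cc3)n2C)n(C)c1=O`, which carries bromo on its aryl ring and methyl groups on the core nitrogens, gives 3690 nM; the gap between the two values lies beyond the usual scatter, though the two compounds differ in more than one place, so no single step can be read from them.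

Compound 3 `CCn1c(=O)c2c(nc(COc3ccc(Br)cc3)n2C)n(CC)c1=O` keeps the core of compound 1 and differs only as follows: bromo in place of methyl on an aromatic carbon. Among the measured compounds shown here, no measured pair isolates this exchange. The step from compound 1 to compound 3 is expected to be a 1.3-fold higher number from compound 1 to compound 3 (0.10 log units; within the scatter), small and not clearly beyond the scatter, with a slight lean towards a weaker value. For compound 3 the expected result in this assay is 1800 nM, within a range of 700 nM to 4500 nM.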

Compound 3, inhibition constant: 264 nM
Compound 3: middle estimate off by 6.8-fold (0.83 log units), on the high side; the whole stated range lies above it.
By their numbers in this assay, from the lowest: compound 3; then compound 1; then compound 2.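

On the core of compound 1, with ethyl groups on the core nitrogens, putting bromo in place of methyl on the aromatic carbon gives a 5.4-fold lower number from compound 1 to compound 3 (0.73 log units; beyond the scatter) in this assay, a step beyond the scatter. Among these compounds, as the first exchange in the set confined to one place, it shows that this position on the aryl ether responds to the group it carries, with the 4-bromophenoxy compound holding the lower number. Nothing available explains the step.

As far as these compounds go, a single exchange sets no trend, so it remains open whether chloro, methoxy or an amine at this position would follow bromo or methyl. Also open, from the compounds shown here alone, is the size of the same exchange on the core of compound 2, which has methyl groups on the core nitrogens.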